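The source may report more compounds than this note shows. Statements on the series, on what has been measured and on what is new or still open speak of the compounds shown alone.

Measured so far:
- compound 1, `CS(=O)(=O)c1ccc2c(c1)CCN2c1ncnc2c(C3CCN(c4ncc(Cl)cn4)CC3)coc12`: 42 nM
- compound 2, `CS(=O)(=O)c1ccc2c(c1)CCN2c1ncnc2c(C3CCN(c4ncc(O)cn4)CC3)coc12`: 391 nM
- compound 3, `CS(=O)(=O)c1ccc2c(c1)CCN2c1ncnc2c(C3CCN(c4ncc(F)cn4)CC3)coc12`: 201 nM

In a functional assay on cells for agonist activity at Glucose-dependent insulinotropic receptor (Homo sapiens), read by a luciferase reporter, with a stated time of 4 h (on this read-out lower numbers stand for an effect already at smaller amounts and higher numbers for an effect only at larger amounts of compound), compound 3 stands second highest of the three numbers. Its nearest neighbour is compound 2, and that gap, a 1.9-fold lower number from compound 2 to compound 3 (0.29 log units; within the scatter), is within the scatter. Its furthest neighbour is compound 1, and that gap, a 4.8-fold higher number from compound 1 to compound 3 (0.68 log units; beyond the scatter), is beyond the scatter.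

Compound 4, `CCc1cnc(N2CCC(c3coc4c(N5CCc6cc(S(C)(=O)=O)ccc65)ncnc34)CC2)nc1`, differs from compound 3 in one place: ethyl in place of fluoro on an aromatic carbon.

For the measured compounds named here, two measured steps touch the same aromatic carbon. Replacing chloro gave a 9.3-fold higher number from compound 1 to compound 2 (0.97 log units; beyond the scatter) and a 4.8-fold higher number from compound 1 to compound 3 (0.68 log units; beyond the scatter), both modest and both beyond the scatter. Going by the values given here, no measured step involves ethyl, so the direction for compound 4 rests on this position being one where a small exchange has shifted the number by a modest amount in either sense. With chloro giving the lowest number and fluoro and hydroxy higher ones, compound 4 is expected to land between those values, and the expected step of a 2.2-fold lower number from compound 3 to compound 4 (0.35 log units; beyond the scatter) is a modest move toward a lower number, possibly within the scatter.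

In this assay compound 4 is therefore estimated at 90 nM, with a range from 25 nM to 320 nM.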

Compound 4, half-maximal effective concentration: 41 nM
Beside the measured number, compound 4's estimate is 2.2-fold (0.34 log units) above it; low and high end bracket the measured number.
By their numbers in this assay, from the lowest: compounds 4 and 1 (each within the scatter of the next); then compounds 3 and 2 (each within the scatter of the next).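

In this assay, putting ethyl on this aromatic carbon gives a 4.9-fold lower number from compound 3 to compound 4 (0.69 log units; beyond the scatter) and a 9.5-fold lower number from compound 2 to compound 4 (0.98 log units; beyond the scatter) and so moves the number well clear of both the fluoro and the hydroxy compounds. For the compounds shown here, the last step, a 1.0-fold lower number from compound 1 to compound 4 (0.01 log units; within the scatter), lies within the scatter, so compound 4 and compound 1 cannot be told apart, and the earlier compounds could not show this: until now chloro was the only group here with a number this low, whereas a plain carbon chain with no halogen now matches it, and fluoro, itself a halogen, goes against any simple rule that halogens do best at this carbon. Nothing measured alongside these numbers accounts for ethyl and chloro reading alike here, or for the gap to fluoro and hydroxy.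

The compounds shown leave open how a shorter methyl, a longer propyl chain, a cyclopropyl ring or an amine would read on this same carbon. They also leave open whether ethyl and chloro would still match on a different core, as all four compounds share one.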